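The source may hold more compounds than are shown below. What is called first, only, known or untested is meant among the compounds shown, and "the series" means these compounds.

Three measured compounds share one core, and a fourth is set beside them. Compound 1 `COc1ccc2[nH]c(-c3cn(-c4ccccc4)nc3-c3ccccc3)nc2c1` carries a methoxy group; in a functional assay on HeLa cells (Homo sapiens) for antiproliferative activity, read by MTT assay, with a stated time of 48 h (on this read-out higher numbers stand for weaker inhibition and lower numbers for stronger inhibition), compound 1 gives 2870 nM. Compound 2 `FC(F)(F)c1ccc2[nH]c(-c3cn(-c4ccccc4)nc3-c3ccccc3)nc2c1` differs from it by trifluoromethyl in place of methoxy on an aromatic carbon, and in this assay compound 2 gives 1920 nM, the step being a 1.5-fold lower number from compound 1 to compound 2 (0.17 log units; within the scatter). Compound 3 `COc1ccc(-c2nn(-c3ccccc3)cc2-c2nc3cc(OC)ccc3[nH]2)cc1` differs from compound 1 by methoxy in place of hydrogen on an aromatic carbon; in this assay compound 3 gives 1140 nM, which amounts to a 2.5-fold lower number from compound 1 to compound 3 (0.40 log units; beyond the scatter). Compound 4 `COc1ccc(-c2nn(-c3ccccc3)cc2-c2nc3cc(C(F)(F)F)ccc3[nH]2)cc1` has not yet been tested. It differs from compound 3 by trifluoromethyl in place of methoxy on an aromatic carbon, the same change that was made between compound 1 and compound 2, at the same place; the two cores differ by methoxy in place of hydrogen on an aromatic carbon. Because the same change earlier gave a 1.5-fold lower number from compound 1 to compound 2 (0.17 log units; within the scatter), a step within the scatter, a similarly small step is expected here: a 1.5-fold lower number from compound 3 to compound 4 (0.18 log units; within the scatter). Compound 4 is therefore expected to give about 760 nM in this assay, with a plausible range from 350 nM to 1700 nM, resting only on that single earlier example and on the value of compound 3.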

Compound 4, half-maximal inhibitory concentration: 2760 nM
Estimate against measurement, compound 4: 3.6-fold (0.56 log units) below, and the stated range ends below it.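

On the core of compound 3, trifluoromethyl in place of methoxy gives a 2.4-fold higher number from compound 3 to compound 4 (0.38 log units; beyond the scatter) in this assay, so the change does not carry over unaltered from the core of compound 1: the same change on two cores in this assay, a 1.5-fold lower number (0.17 log units; within the scatter) from compound 1 to compound 2 and a 2.4-fold higher number (0.38 log units; beyond the scatter) from compound 3 to compound 4, 3.6-fold (0.56 log units) apart, beyond the scatter of two such steps

Read the other way, methoxy in place of hydrogen on an aromatic carbon gives a 1.4-fold higher number from compound 2 to compound 4 (0.16 log units; within the scatter), which also departs from its earlier counterpart: the same change on two cores in this assay, a 2.5-fold lower number (0.40 log units; beyond the scatter) from compound 1 to compound 3 and a 1.4-fold higher number (0.16 log units; within the scatter) from compound 2 to compound 4, 3.6-fold (0.56 log units) apart, beyond the scatter of two such steps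

Both comparisons rest on the same four compounds, so they are one result seen from two sides: the effects of the two changes are not additive in this set, but the data do not show why, or whether this holds on any other core.

The compounds shown carry only methoxy, trifluoromethyl or hydrogen at the places that change. On these data alone, whether an amine, a carboxylic acid or a longer chain at those places would depend on the core in the same way remains open.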